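This account rests on a few compounds, and the source may have more. Where it says the series, first, only, none or still open, it means among the compounds named here.

Compound 1, `CN1CCN(c2nc3ccccc3n2CCO)CC1`: 410 nM 
Compound 2, `CCCCN1CCCN(c2nc3ccccc3n2CCOCC)CC1`: 8.4 nM 
Compound 3, `CCCN1CCN(c2nc3ccccc3n2CCOCC)CC1`: 16 nM 

In a functional assay on ileum for inhibition of histamine H1 receptor (Cavia porcellus) (a higher number here means a weaker inhibitor, a lower number a stronger inhibitor), compound 1 gives 410 nM, the highest of the three numbers. Compound 3 gives 16 nM and compound 2 gives 8.4 nM in this assay, and both sit below compound 1 by more than the usual scatter, so compound 1 is the weakest inhibitor of the three. Within the data shown here, compounds 2 and 3 differ from compound 1 in several places at once, so no single step between measured compounds can be read from them.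

Compound 4, `CN1CCN(c2nc3ccccc3n2CCOCCO)CC1`, has not yet been measured. It differs from compound 1 in one place: 2-hydroxyethyl in place of hydrogen on an oxygen on a saturated carbon. The change keeps a hydrogen-bond donor at the end of the chain and adds an acceptor, but lengthens the side chain on the core of compound 1. Among the measured compounds shown here, with no measured step of this kind to lean on, the expected step from compound 1 to compound 4 in this assay is small, a 1.4-fold lower number from compound 1 to compound 4 (0.14 log units; within the scatter), and may well stay within the scatter. Compound 4 is therefore estimated at 300 nM, within a range from 80 nM to 1200 nM.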

Compound 4, half-maximal inhibitory concentration: 42 nM
Estimate against measurement, compound 4: 7.1-fold (0.85 log units) above, and the stated range ends above it.
By their numbers in this assay, from the lowest: compounds 2 and 3 (each within the scatter of the next); then compound 4; then compound 1.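

In this assay, putting 2-hydroxyethyl in place of hydrogen on this oxygen on a saturated carbon gives a 9.8-fold lower number from compound 1 to compound 4 (0.99 log units; beyond the scatter), a step beyond the scatter and the first that can be read from one change in one place. It shows that the hydroxy end of the side chain on the core of compound 1 is not a fixed requirement: the chain can grow there and inhibition gets stronger, not weaker. Nothing available explains why this step occurs.

This single step cannot separate the effect of the added length from that of the added oxygen or the hydroxy group at the new chain end. From the compounds shown here alone, how a 2-aminoethyl or a longer chain such as 3-hydroxypropyl on this oxygen would compare remains open.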